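Ortho halogen swap on the benzyl arm of the triazole

The source may report more compounds than this note shows. Statements on the series, on what has been measured and on what is new or still open speak of the compounds shown alone.

Compound 1 `Cc1ccc(/C=C2\CN(C(=S)SCc3cn(Cc4ccc(F)cc4)nn3)C/C(=C\c3ccc(C)cc3)C2=O)cc1` carries a 4-fluorophenyl on the saturated chain carbon bound to the aromatic nitrogen; in a functional assay on PC-3 cells (Homo sapiens) for cytotoxicity, read by MTT assay, with a stated time of 24 h (a lower number here means a stronger inhibitor, a higher number a weaker inhibitor), compound 1 gives 45500 nM. Compound 2 `Cc1ccc(/C=C2\CN(C(=S)SCc3cn(Cc4cccc(Cl)c4)nn3)C/C(=C\c3ccc(C)cc3)C2=O)cc1` bears a 3-chlorophenyl at the same place. In this assay compound 2 reaches only a limit, > 80000 nM. Compound 3 `Cc1ccc(/C=C2\CN(C(=S)SCc3cn(Cc4ccccc4F)nn3)C/C(=C\c3ccc(C)cc3)C2=O)cc1` bears a 2-fluorophenyl there. In this assay compound 3 likewise reaches only a limit, > 80000 nM, so compound 3 sits at the weak end of the numbers shown, with no exact value; the same is true of one further compound, as the limit of > 80000 nM in this assay, at which 2 of the 3 values shown sit, records.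

The steps that touch this place are an at least 1.7-fold higher number from compound 1 to compound 3 (0.24 log units; that floor lies within the scatter) and a step that the two limits leave unreadable from compound 2 to compound 3.

Compound 4 `Cc1ccc(/C=C2\CN(C(=S)SCc3cn(Cc4ccccc4Cl)nn3)C/C(=C\c3ccc(C)cc3)C2=O)cc1` is the unmeasured member. chloro in place of fluoro on an aromatic carbon The change keeps the substituent at the same place on the ring and exchanges one halogen for another.

Within the data shown here, no step in the set separates a fluoro from a chloro at a single ring position, and the only reading of compound 3 is a limit. The expectation is therefore that compound 4 stays near that limit, an expected step that the limit leaves unreadable from compound 3 to compound 4, nothing beyond the scatter in either direction. The estimated value for compound 4 in this assay is 100000 nM, with a range from 40000 nM to 250000 nM.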

Compound 4, half-maximal inhibitory concentration: > 80000 nM
Compound 4 was reported as a limit; the forecaster's own chance of this, stated with the estimate: 70%; the middle value does not contradict the limit.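

Chloro in place of fluoro on this aromatic carbon, ortho to a large group, gives a second halogen at the same ring position, and in this assay neither the 2-fluorobenzyl nor the 2-chlorobenzyl arm yields an exact value, so the steps among compound 2, compound 3 and compound 4 cannot be read. Among these compounds, the one readable new step is an at least 1.7-fold higher number from compound 1 to compound 4 (0.24 log units; that floor lies within the scatter), so this floor does not separate the two arms beyond the scatter. The only exact value among the four compounds therefore stays with the 4-fluorophenyl arm, and the other three arms give only the same limit: the limit of > 80000 nM in this assay, at which 3 of the 4 values shown sit.

On these data alone, the size of any fluoro-to-chloro difference at this position remains open, as does whether any arm on the shared core can give a clearly lower number in this assay. Also open, as far as these compounds go, is how the series reads with an amine or a carboxylic acid on this phenyl ring, or with a longer chain in place of the benzyl carbon.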